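This account rests on a few compounds, and the source may have more. Where it says the series, first, only, none or still open, it means among the compounds named here.

Measured so far in a functional assay with Alpha-1A adrenergic receptor (Homo sapiens) as the target, read by calcium flux; on this read-out higher numbers stand for larger maximal responses and lower numbers for smaller maximal responses:
compound 1 `CCn1ncnc1-c1ccccc1NCC1=NCCN1` gives 107%;
compound 2 `c1ccc(-c2nc[nH]n2)c(NCC2=NCCN2)c1` gives 135%;
compound 3 `CCCCn1ncnc1-c1ccccc1NCC1=NCCN1` gives 86%.

Compound 2 stands highest of the three numbers; compound 1 gives 107% and compound 3 gives 86%, both beyond the scatter below compound 2. Compound 4 `Cn1ccnc1-c1ccccc1NCC1=NCCN1` differs from compound 2 in one place: 1-methyl-1H-imidazol-2-yl in place of 1H-1,2,4-triazol-3-yl on an aromatic carbon.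

Only one measured step exists among these compounds, and it is of a different kind: a number 21 percentage points lower from compound 1 to compound 3 (beyond the scatter). It shows that enlarging the substituent on the aromatic nitrogen of the five-membered ring, in that pair, went with a lower maximal response. Compound 1 and compound 2 are not a single-step pair, so their values are taken only as they stand. Compound 4 carries a methyl on a ring nitrogen where compound 2 carries a hydrogen, and its ring has one hetero atom fewer. The expectation is a lower response than compound 2, of a size like the gap between compound 2 and compound 1, so the step is estimated at a number 30 percentage points lower from compound 2 to compound 4 (beyond the scatter). Compound 4 is therefore expected to give about 105%, within 80% to 130%.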

Compound 4, largest response reached (reported as maximal response), in percent of the reference or control that the assay uses: 88%
The estimate for compound 4 lay 17 percentage points above the measured number; measured number inside the range.
By their numbers in this assay, from the lowest: compounds 3 and 4 (each within the scatter of the next); then compound 1; then compound 2.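

In this assay, within the data shown here, the exchange of 1H-1,2,4-triazol-3-yl for 1-methyl-1H-imidazol-2-yl on this aromatic carbon gives a number 47 percentage points lower from compound 2 to compound 4 (beyond the scatter) and is the first measured step to change the five-membered aromatic ring itself, showing that the maximal response here also shifts with the ring and not only with the chain on its nitrogen. The entering group differs at once in three ways, with a methyl, no hydrogen-bond donor and one ring hetero atom fewer, and this single step cannot assign the drop to any one of them. No measurement at hand explains the drop.

The compounds shown leave open where 1H-imidazol-2-yl, which lacks the methyl, would fall on this aromatic carbon. They also leave open how 1-methyl-1H-1,2,4-triazol-5-yl would compare there.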